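Acetamido for Trifluoromethyl on the Sulfonyl Aryl Ring

The source may hold more compounds than are shown below. What is called first, only, known or untested is meant among the compounds shown, and "the series" means these compounds.

Measured compounds:
compound 1 `O=C1/C(=C/c2ccc(F)cc2)CN(S(=O)(=O)c2ccc(O[N+](=O)[O-])cc2)C/C1=C\c1ccc(F)cc1` gives 16200 nM
compound 2 `O=C1/C(=C/c2ccc(F)cc2)CN(S(=O)(=O)c2ccc(C(F)(F)F)cc2)C/C1=C\c1ccc(F)cc1` gives 13500 nM

Both numbers come from an ADME assay on L02 cells (Homo sapiens) for cytotoxicity, read by MTT assay, with a stated time of 24 h; a higher number here means a weaker inhibitor, a lower number a stronger inhibitor. Within the data shown here, compound 2 holds the lowest of the two numbers, and its nearest neighbour is compound 1, but the only measured step, a 1.2-fold lower number from compound 1 to compound 2 (0.08 log units; within the scatter), falls within the scatter, so the two compounds cannot be placed in any order.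

Compound 3 `CC(=O)Nc1ccc(S(=O)(=O)N2C/C(=C\c3ccc(F)cc3)C(=O)/C(=C/c3ccc(F)cc3)C2)cc1` differs from compound 2 in one place: acetamido in place of trifluoromethyl on an aromatic carbon. Among the measured compounds shown here, the single measured step concerns the same position of the same ring, yet it exchanges a different pair of groups, and no measurement involves an acetamido group. For the measured compounds named here, the one step known there was within the scatter, so a step beyond the scatter is not expected here either, and compound 3 is expected to lie close to compound 2, with a 1.2-fold higher number from compound 2 to compound 3 (0.07 log units; within the scatter). Compound 3 is therefore estimated at 16000 nM, with a range from 6000 nM to 45000 nM.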

Compound 3, half-maximal inhibitory concentration: 19400 nM
For compound 3 the middle estimate is 1.2-fold (0.08 log units) below the measured one; low and high end bracket the measured number.
By their numbers in this assay, from the lowest: compounds 2, 1 and 3 (each within the scatter of the next).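

In this assay the change places a hydrogen-bond donor and a hydrogen-bond acceptor on the aromatic carbon where trifluoromethyl carries neither, yet it gives a 1.4-fold higher number from compound 2 to compound 3 (0.16 log units; within the scatter) and the exchange of nitrooxy for acetamido at that same place gives a 1.2-fold higher number from compound 1 to compound 3 (0.08 log units; within the scatter) as well. This position has now carried three different groups, and all three compounds stand within the scatter of one another, so the lack of a readable step now extends to a group with a nitrogen-bound acyl chain. No measurement shown accounts for this result.

The compounds shown leave open whether a free amine, a carboxylic acid or a longer acyl chain at this place would also stay within the scatter. They also leave open whether these exchanges would behave alike if the fluorine atoms of the shared core gave way to chlorine or hydrogen.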